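From 3-cyanophenyl to 4-chlorophenyl at the assay limit

The source may report more compounds than this note shows. Statements on the series, on what has been measured and on what is new or still open speak of the compounds shown alone.

In an ADME assay on MCF-10A cells (Homo sapiens) for inhibition, with a stated time of 48 h (a higher number here means a weaker inhibitor, a lower number a stronger inhibitor), compound 1 `Cc1cccc(-c2noc([C@@H]3CCCN3C(=O)Nc3ccc(Cl)cc3)n2)c1` gives only a limit (> 50000 nM). Compound 2 `O=C(Nc1ccc(Cl)cc1)N1CCC[C@H]1c1nc(-c2cccc(F)c2)no1` also gives only a limit (> 50000 nM). Compound 3 `N#Cc1cccc(-c2noc([C@@H]3CCCN3C(=O)Nc3ccc(Cl)cc3)n2)c1` likewise gives only a limit (> 50000 nM) and so offers no number to start from.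

The change to compound 4 `O=C(Nc1ccc(Cl)cc1)N1CCC[C@H]1c1nc(-c2ccc(Cl)cc2)no1` is 4-chlorophenyl in place of 3-cyanophenyl on an aromatic carbon

Nearest are a step that the two limits leave unreadable from compound 1 to compound 2 and a step that the two limits leave unreadable from compound 1 to compound 3 and also a step that the two limits leave unreadable from compound 2 to compound 3 with no size to carry over. Given the limit of > 50000 nM in this assay, at which 3 of the 3 values shown sit, no direction can be read, and nothing beyond the scatter is expected in this assay for the estimated move (a number no higher from compound 3 to compound 4 (the limit leaves the size open)). Compound 4 is estimated at 50000 nM (expected range 20000 nM to 100000 nM).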

Compound 4, half-maximal inhibitory concentration: > 50000 nM
Compound 4: only a limit was reported (the forecaster's own chance of this, stated with the estimate: 85%); the middle value sits exactly at the limit.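

Compound 4 adds no readable step against compound 1, compound 2 or compound 3 in this assay, because all four rest on one limit: the limit of > 50000 nM in this assay, at which 4 of the 4 values shown sit.

Still open, from the compounds shown here alone, is whether exchanging these groups on the shared core changes inhibition at all.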